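Swapping Bromophenyl for Dimethoxyphenyl on a Shared Core

The source may report more compounds than this note shows. Statements on the series, on what has been measured and on what is new or still open speak of the compounds shown alone.

Of the compounds shown here, two built on the same core have been tested in an ADME assay on HUVEC cells (Homo sapiens) for antiproliferative activity, read by MTT assay, with a stated time of 48 h; a higher number here means a weaker inhibitor, a lower number a stronger inhibitor. Within the data shown here, compound 2, `N#CC1=C(N)Oc2c(N)cc3nc4ccccc4nc3c2C12C(=O)N(Cc1cnnn1-c1ccccc1Br)c1ccccc12`, gives 34200 nM, the only actual number reported so far. Compound 1, `Cc1ccc(-n2nncc2CN2C(=O)C3(C(C#N)=C(N)Oc4c3c3nc5ccccc5nc3c3ccccc43)c3ccccc32)cc1Cl`, reaches only the limit of the measurement, > 50000 nM; this is the limit of > 50000 nM in this assay, at which 1 of the 2 values shown sits. Among the measured compounds shown here, no pair of measured compounds differs in just one place, so there is no measured step to lean on. Compound 3, `COc1ccc(OC)c(-n2nncc2CN2C(=O)C3(C(C#N)=C(N)Oc4c(N)cc5nc6ccccc6nc5c43)c3ccccc32)c1`, is the next compound to be tested: it differs from compound 2 by 2,5-dimethoxyphenyl in place of 2-bromophenyl on an aromatic nitrogen. The 2-bromophenyl leaves, and 2,5-dimethoxyphenyl enters, both sitting on an aromatic nitrogen. Compound 3 is expected to show a step of a 1.0-fold higher number from compound 2 to compound 3 (0.01 log units; within the scatter), none larger than the usual scatter in either direction. Compound 3 is therefore estimated at 35000 nM, ranging from 12000 nM to 100000 nM.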

Compound 3, half-maximal inhibitory concentration: > 50000 nM
Compound 3: a limit, no number; the forecaster's own chance of this, stated with the estimate: 35%; at least 1.4-fold (0.15 log units) between middle value and limit.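

Among these compounds, this is the first measured step at this position, on an aromatic nitrogen of the five-membered ring: in this assay, 2,5-dimethoxyphenyl in place of 2-bromophenyl gives an at least 1.4-fold higher number from compound 2 to compound 3 (0.16 log units; that floor lies within the scatter). The result for compound 3 is a limit and not a number, so this step is only a floor, and that floor lies within the scatter. On these data alone, the true size of the change therefore stays unknown, although nothing here points to a stronger inhibitor, and the readings are hard to separate further because they crowd at the top of the range: the limit of > 50000 nM in this assay, at which 2 of the 3 values shown sit.

Still open, as far as these compounds go, is whether a plain phenyl, a pyridine ring or a 4-aminophenyl on this nitrogen would give a real number well clear of the limit. The compounds shown also leave open whether any group at this position can shift the value beyond the scatter.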